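The compounds below may be only part of what the source reports. "The series", "measured", "known", "first", "only" and "open" are said of these compounds alone.

Working notes on the series, read in an ADME assay on NIH3T3 cells (Mus musculus) for cytotoxicity; a higher number here means that more compound is needed for the effect, a lower number that less compound is needed. Compound 1 `COc1cccc(Nc2cccc(Cn3ccnc3)c2)c1` gives > 100000 nM, which is a limit of the assay and not a number. For the measured compounds named here, compound 2 `c1ccc(-c2cccc(Oc3cccc(Cn4ccnc4)c3)c2)cc1` gives 34000 nM, the only true number so far in this assay.

The next entry is compound 3 `c1ccc(Oc2cccc(Cn3ccnc3)c2)cc1`, which has hydrogen in place of phenyl on an aromatic carbon, meta to a large group: hydrogen in place of phenyl on an aromatic carbon. Going by the values given here, no measured pair sizes this change, so the expectation has no direct precedent. Starting from compound 2 at 34000 nM, a moderate move toward a higher number is expected, meaning more compound needed for the effect. The estimated change is a 2.1-fold higher number from compound 2 to compound 3 (0.31 log units; beyond the scatter). For compound 3 the estimate is 70000 nM, with an expected range from 30000 nM to 160000 nM.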

Compound 3, half-maximal effective concentration: > 100000 nM
Compound 3 was reported as a limit; the forecaster's own chance of this, stated with the estimate: 35%; middle value at least 1.4-fold (0.15 log units) from the limit.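

In this assay, for the compounds shown here, hydrogen in place of phenyl on this aromatic carbon, meta to a large group, gives the first sized step: an at least 2.9-fold higher number from compound 2 to compound 3 (0.46 log units; beyond the scatter). Compound 3 gives > 100000 nM, which is a limit of the assay and not a number. The step therefore fixes only the direction and a minimum size for this change, and the phenyl of compound 2 is the one difference between a true number and a limit in this pair, with the reading capped by the range of the assay: the limit of > 100000 nM in this assay, at which 2 of the 3 values shown sit.

On these data alone, how far compound 3 lies past its limit stays open, so the full size of the step cannot be read. Also open, as far as these compounds go, is whether a benzyl group, an amine or a carboxylic acid on this aromatic carbon would give a true number, as phenyl does, or a limit, as hydrogen does.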